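The compounds below may be only part of what the source reports. "The series", "measured", "known", "first", "only" and "open" are said of these compounds alone.

Measured so far in an ADME assay on MRC5 cells (Homo sapiens) for cytotoxicity, read by MTT assay; on this read-out higher numbers stand for lower toxicity in this test and lower numbers for higher toxicity in this test:
- compound 1, `CCCCCCC#Cc1cn([C@@H]2O[C@H](CO)[C@@H](O)[C@H]2O)c(=O)[nH]c1=O` — 15700 nM
- compound 2, `O=c1[nH]cc(C#CC2CCCCC2)c(=O)[nH]1` — 62800 nM

On these two numbers compound 1 stands at the lower end: its value in this assay sits clearly under that of compound 2, a gap described as beyond the usual scatter, so compound 1 is the more toxic of the two in this test. Compound 2 has a different core without the sugar, so nothing is counted between it and compound 1.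

The step followed here goes from compound 1 to compound 3, `CCCCC#Cc1cn([C@@H]2O[C@H](CO)[C@@H](O)[C@H]2O)c(=O)[nH]c1=O`, which is not yet measured. The change is hydrogen in place of ethyl on a saturated chain carbon, four bonds along the chain from a triple-bonded carbon. Going by the values given here, no measured pair shows this kind of trimming, so there is no number to lean on. Compound 3 is expected to come out close to compound 1, with at most a small move toward a higher number, a 1.4-fold higher number from compound 1 to compound 3 (0.15 log units; within the scatter), probably within the scatter. The estimate for compound 3 is 22000 nM, within 9000 nM to 60000 nM.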

Compound 3, half-maximal cytotoxic concentration: 11600 nM
For compound 3 the middle estimate is 1.9-fold (0.28 log units) above the measured one; the range from low to high includes it.
By their numbers in this assay, from the lowest: compounds 3 and 1 (each within the scatter of the next); then compound 2.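

Putting hydrogen in place of ethyl on a saturated chain carbon, four bonds along the chain from a triple-bonded carbon, gives a 1.4-fold lower number from compound 1 to compound 3 (0.13 log units; within the scatter) in this assay. Going by these compounds alone, this is the first pair that differs in one place, and it shows that removing this ethyl leaves the read-out indistinguishable from that of the longer chain. Nothing on hand explains this outcome, so the reading stops at the numbers.

Going by these compounds, a single step along the chain cannot establish a trend with chain length, so it remains open whether a longer chain would also leave the number within the scatter. On these data alone, it is equally open how this test would respond to an amine or a carboxylic acid at the end of the chain.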